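Amine replacements on the shared core: outlook for compound 4

The source may report more compounds than this note shows. Statements on the series, on what has been measured and on what is new or still open speak of the compounds shown alone.

Compound 1 `O=C(CCc1ccc(C(F)(F)F)cc1)Nc1ccc2nc(N3CC4CC3CN4)ccc2c1` — 490 nM
Compound 2 `O=C(CCc1ccc(C(F)(F)F)cc1)Nc1ccc2nc(N3CCC4(CCNC4)C3)ccc2c1` — 140 nM
Compound 3 `CCN(CC)c1ccc2cc(NC(=O)CCc3ccc(C(F)(F)F)cc3)ccc2n1` — 830 nM

In a functional assay on HEK293 cells for activation of melanin-concentrating hormone receptor 1 (Rattus norvegicus), read by inositol phosphate accumulation (on this read-out higher numbers stand for an effect only at larger amounts of compound and lower numbers for an effect already at smaller amounts), compound 3 stands highest of the three numbers: the step of a 1.7-fold higher number from compound 1 to compound 3 (0.23 log units; within the scatter) lies within the scatter, the step of a 5.9-fold higher number from compound 2 to compound 3 (0.77 log units; beyond the scatter) beyond it. Compound 4 `O=C(CCc1ccc(C(F)(F)F)cc1)Nc1ccc2nc(N3CC4CCC3C4)ccc2c1` changes the amine: a group of 7 heavy atoms (6 carbon, 1 nitrogen; one five-membered non-aromatic ring of carbon only, one five-membered non-aromatic ring with 1 hetero atom) in place of a group of 5 heavy atoms (4 carbon, 1 nitrogen; no ring), on an aromatic carbon. Among the measured compounds shown here, the steps that bear on this are those from the cyclic diamines of compound 1 and compound 2 to the open chain of compound 3, both pointing to a lower number when a ring system returns. Compound 4 carries no second nitrogen, so the expectation is anchored near compound 1 with its 490 nM in this assay. Compound 4 is expected to show a 1.7-fold lower number from compound 3 to compound 4 (0.22 log units; within the scatter). Compound 4 is estimated at 500 nM, within 200 nM to 1500 nM.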

Compound 4, half-maximal effective concentration: 150 nM
Estimate against measurement, compound 4: 3.3-fold (0.52 log units) above; the measured number lies below the stated range.
By their numbers in this assay, from the lowest: compounds 2 and 4 (each within the scatter of the next); then compounds 1 and 3 (each within the scatter of the next).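

In this assay, a 5.5-fold lower number from compound 3 to compound 4 (0.74 log units; beyond the scatter) shows that at this place, next to the ring nitrogen, a two-ring group with 1 nitrogen separates from the open diethylamino group, though both carry 1 nitrogen. With a 1.1-fold higher number from compound 2 to compound 4 (0.03 log units; within the scatter), a group with 2 nitrogen is not required for a number at this level, while a 3.3-fold lower number from compound 1 to compound 4 (0.51 log units; beyond the scatter) shows that an equal count of 7 heavy atoms does not fix the number. Nothing measured here accounts for these steps.

Open, on these data alone, is how single-ring amines such as piperidine or morpholine would compare at this place.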